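Swapping fluoro for methyl on the aryl ring

This account rests on a few compounds, and the source may have more. Where it says the series, first, only, none or still open, it means among the compounds named here.

In a functional assay on MDA-MB-435 cells (Homo sapiens) for antiproliferative activity (on this read-out lower numbers stand for stronger inhibition of growth and higher numbers for weaker inhibition of growth), compound 1 `Cc1cc(C)c2c(O)cc(-c3cccc(F)c3)nc2n1` is reported only as a limit, < 10 nM. Two relatives with larger aryl groups give actual numbers. In this assay, compound 2 `Cc1cc(C)c2c(O)cc(-c3cccc4ccccc34)nc2n1` gives 191 nM, and compound 3 `Cc1ccnc2nc(-c3ccc4ccccc4c3)cc(O)c12` gives 204 nM. These two values lie within the usual scatter of each other, and both stand for weaker inhibition of growth than the limit reached by compound 1.

The next structure, compound 4 `Cc1cccc(-c2cc(O)c3c(C)cc(C)nc3n2)c1`, keeps the core of compound 1 and changes one substituent: methyl in place of fluoro on an aromatic carbon, on a six-membered aromatic ring of carbon only, meta to a large group (methyl in place of fluoro on an aromatic carbon). For the measured compounds named here, no pair of measured compounds isolates this change, so the data give no direct size for it. Going by the values given here, the only anchor is compound 1, whose limit of < 10 nM leaves its true value open. A modest loss of growth inhibition in this assay is expected, not much beyond the scatter, and the expected step is an at least 2.0-fold higher number from compound 1 to compound 4 (0.30 log units; that floor lies within the scatter). The estimate for compound 4 is 20 nM, with an expected range from 5 nM to 100 nM.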

Compound 4, concentration for 50% growth inhibition: 20000 nM
For compound 4 the middle estimate is 1000-fold (3.00 log units) below the measured one; the whole stated range lies below it.
By their numbers in this assay, from the lowest: compounds 2 and 3 (each within the scatter of the next); then compound 4. At a limit, below all of these: compound 1.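

In this assay, the exchange of fluoro for methyl on an aromatic carbon, meta to a large group, replaces one heavy atom with one heavy atom, with no hydrogen-bond donor or acceptor and no net charge on either side, and still comes with an at least 2000-fold higher number from compound 1 to compound 4 (3.30 log units; beyond the scatter). For the compounds shown here, this shows that growth inhibition on this read-out depends strongly on which group sits at this position, something no earlier pair could show, since none isolated a change there. The printed step is only a floor, and the real gap may be larger, because one end of it is a limit and not a number: the limit of < 10 nM in this assay, at which 1 of the 4 values shown sits.

The compounds shown leave open whether fluoro is specifically favoured at this position or methyl is specifically disfavoured, and a chloro, methoxy or trifluoromethyl group, or plain hydrogen, on the same carbon would help to separate those two readings. Also open, on these data alone, is whether the same swap would carry a step of similar size on a different substitution pattern of the shared core.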